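This account rests on a few compounds, and the source may have more. Where it says the series, first, only, none or still open, it means among the compounds named here.

Among the three measured compounds, compound 3 `Cc1ccc2ncc(-c3cnc(Nc4ncccc4F)nc3)n2n1` stands highest in a physicochemical assay for lipophilicity (on this read-out lower numbers stand for lower lipophilicity and higher numbers for higher lipophilicity), giving 2.5. Compound 1 `N[C@H]1CC[C@H](Nc2ccc3ncc(-c4cnc(Nc5ccccc5)nc4)n3n2)CC1` gives 1.6 and compound 2 `N[C@H]1CC[C@H](Nc2ccc3ncc(-c4cnc(Nc5ncc(C(F)(F)F)cc5F)nc4)n3n2)CC1` gives 1.6, both lower by more than the usual scatter; each carries a primary amine on a saturated ring, which compound 3 lacks. For the measured compounds named here, the only measured step, no change at the digits printed from compound 1 to compound 2 (within the scatter), concerns the anilino part and does not touch the change now considered. Compound 4 `Fc1cccnc1Nc1ncc(-c2cnc3ccc(N[C@H]4CCNC4)nn23)cn1` differs from compound 3 as follows: (pyrrolidin-3-yl)amino in place of methyl on an aromatic carbon. Guided by the lower values of compound 1 1.6 and compound 2 1.6, a downward step of a number 1.10 log units lower from compound 3 to compound 4 (beyond the scatter) is expected, so compound 4 is estimated at 1.4, between 0.7 and 2.1.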

Compound 4, distribution coefficient: 0.4
The estimate for compound 4 lay 1.00 log units above the measured number; measured number outside the range, below it.
By their numbers in this assay, from the lowest: compound 4; then compounds 1 and 2 (each within the scatter of the next); then compound 3.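

For the compounds shown here, this is the first measured change at this place, on an aromatic carbon next to the ring nitrogen, and in this assay (pyrrolidin-3-yl)amino in place of methyl gives a number 2.10 log units lower from compound 3 to compound 4 (beyond the scatter). The step is large and lies beyond the scatter, so this position strongly affects the read-out. Nothing shown explains the size of this step. From the compounds shown here alone, it remains open whether (tetrahydrofuran-3-yl)amino, with oxygen in the ring instead of nitrogen, would give a similar step. An open-chain ethylamino group at this position is equally unresolved.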